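The compounds below may be only part of what the source reports. "The series", "measured", "known", "first", "only" and "open" are said of these compounds alone.

Compound 3 `Nc1ncnc2c1c(-c1cnc3[nH]ccc3c1)nn2CCCCCC(=O)NO` shares its core with the rest of the series, but in a functional assay on Bel-7402 cells (Homo sapiens) for inhibition, read by MTT assay, with a stated time of 72 h (on this read-out lower numbers stand for stronger inhibition and higher numbers for weaker inhibition), compound 3 is reported as "not determined" (no result reported); no result was reported, so compound 3 stands at no fixed place on the scale. The two measured analogues set the range: compound 1 `CNC(=O)CCCCCCCn1nc(-c2cnc3[nH]ccc3c2)c2c(N)ncnc21` gives 17400 nM in this assay, and compound 2 `Nc1ncnc2c1c(-c1cnc3[nH]ccc3c1)nn2CCCCCCCCC(=O)NO` gives 18900 nM. Among the compounds with values here, the only measured step, a 1.1-fold higher number from compound 1 to compound 2 (0.04 log units; within the scatter), exchanges the terminal group at the end of the chain and stays within the scatter.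

Compound 4 `Nc1ncnc2c1c(-c1cnc3[nH]ccc3c1)nn2CCCCCCCCCC(=O)NO` differs from compound 3 by 4-(hydroxycarbamoyl)butyl in place of hydroxycarbamoyl on a saturated chain carbon, five bonds along the chain from an aromatic nitrogen. Within the data shown here, no measured step matches this change in kind, since the measured step swaps the chain end rather than lengthening it. The closest anchor is compound 2, which carries the same hydroxamic chain end and whose value in this assay is 18900 nM. Among the measured compounds shown here, with both measured values near each other and the one step within the scatter, nothing in the data points to a shift beyond the scatter for chain lengthening. Compound 4 is therefore expected near 18000 nM, estimated between 7000 nM and 45000 nM.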

Compound 4, half-maximal inhibitory concentration: 42100 nM
Beside the measured number, compound 4's estimate is 2.3-fold (0.37 log units) below it, within the range that was stated.
By their numbers in this assay, from the lowest: compounds 1 and 2 (each within the scatter of the next); then compound 4.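

Lengthening the chain that ends in hydroxycarbamoyl gives the first move in this assay that lies beyond the scatter (a 2.2-fold higher number from compound 2 to compound 4 (0.35 log units; beyond the scatter)), and the step is modest. The step that also changes the chain end is of similar modest size (a 2.4-fold higher number from compound 1 to compound 4 (0.38 log units; beyond the scatter)), whereas the earlier exchange of chain end alone stayed within the scatter (a 1.1-fold higher number from compound 1 to compound 2 (0.04 log units; within the scatter)). Among these three compounds, the clearly higher number therefore belongs to the compound with the longest chain, compound 4, and no measurement shown accounts for the rise.

Going by these compounds, compound 3 carries no number, so the effect of the shorter chain on this read-out stays open. Also open, on these data alone, is whether a longer chain than that of compound 4, or a carboxylic acid in place of the hydroxycarbamoyl end, would shift the number further.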